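The source may hold more compounds than are shown below. What is called first, only, known or untested is meant among the compounds shown, and "the series" means these compounds.

compound 1 `COc1cc(-c2ccnc3cc(-c4ccc(C(F)(F)F)cc4)nn23)cc(OC)c1OC`: 1840 nM
compound 2 `COc1cc(-c2ccnc3cc(-c4cn(C)c5ccccc45)nn23)cc(OC)c1OC`: 399 nM
compound 3 `COc1cc(-c2ccnc3cc(-c4ccc5cnn(C)c5c4)nn23)cc(OC)c1OC`: 97 nM

These values come from a functional assay on HeLa cells (Homo sapiens) for inhibition, read by CCK-8 assay, with a stated time of 48 h; on this read-out lower numbers stand for stronger inhibition and higher numbers for weaker inhibition. Compound 3 has the lowest number of the three, and both steps leading to it lie beyond the scatter: a 19-fold lower number from compound 1 to compound 3 (1.28 log units; beyond the scatter) and a 4.1-fold lower number from compound 2 to compound 3 (0.61 log units; beyond the scatter).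

The step followed here is 3-amino-4-methoxyphenyl in place of 1-methyl-1H-indazol-6-yl on an aromatic carbon, which gives compound 4 `COc1ccc(-c2cc3nccc(-c4cc(OC)c(OC)c(OC)c4)n3n2)cc1N`, with 3-amino-4-methoxyphenyl in place of 1-methyl-1H-indazol-6-yl on an aromatic carbon. All three measured steps change this same group. Besides the two above, there is a 4.6-fold lower number from compound 1 to compound 2 (0.66 log units; beyond the scatter), so steps from modest to large are on record at this place. Within the data shown here, compound 4 again carries a substituted phenyl, like compound 1 at 1840 nM, but no measured compound carries the amino group, so that comparison is weak. A modest step to a higher number in this assay is expected, though the direction is uncertain. The estimated change is a 1.9-fold higher number from compound 3 to compound 4 (0.27 log units; within the scatter). For compound 4 the expected value is 180 nM, with an estimated range of 40 nM to 800 nM.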

Compound 4, half-maximal inhibitory concentration: 283 nM
Beside the measured number, compound 4's estimate is 1.6-fold (0.20 log units) below it; low and high end bracket the measured number.
By their numbers in this assay, from the lowest: compound 3; then compounds 4 and 2 (each within the scatter of the next); then compound 1.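

In this assay, a phenyl at this position need not read as weakly as compound 1 did: a 6.5-fold lower number from compound 1 to compound 4 (0.81 log units; beyond the scatter), so the outcome depends on the substituents and not only on the phenyl ring. The fused 1-methyl-1H-indazol-6-yl still stands apart from the new group, with a 2.9-fold higher number from compound 3 to compound 4 (0.47 log units; beyond the scatter), whereas a 1.4-fold lower number from compound 2 to compound 4 (0.15 log units; within the scatter) places 3-amino-4-methoxyphenyl and 1-methyl-1H-indol-3-yl within the scatter of each other. No supporting data bear on why these numbers differ.

The compounds shown do not separate the contribution of the amino group from that of the methoxy group within 3-amino-4-methoxyphenyl. As far as these compounds go, how a phenyl carrying a carboxylic acid or a morpholine ring would read at this position also stays open.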